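Swapping a phenyl for a piperidine on a porcupine inhibitor

A few compounds are considered here, and "the series" means these few. Any claim that something is new, unique, unknown or untested is made for them only; others in the source may bear on it.

For the measured compounds named here, compound 2 `O=C(CSc1nc2c(c(=O)n1-c1ccccc1)SCC2)Nc1ccc(-c2ccccc2)cc1` is the only member of this small set with a numeric result: in an assay on L cells for inhibition of Protein-serine O-palmitoleoyltransferase porcupine (Mus musculus), read by reporter gene assay, with a stated time of 24 h (on this read-out higher numbers stand for an effect only at larger amounts of compound and lower numbers for an effect already at smaller amounts), compound 2 gives 0.75 nM. Compound 1 `CN(C)c1ccc(NC(=O)CSc2nc3c(c(=O)n2-c2ccccc2)SCC3)cc1` reaches only a limit of the assay, > 1000 nM, in this assay. Going by the values given here, the one measured step, an at least 1300-fold lower number from compound 1 to compound 2 (3.12 log units; beyond the scatter), is large, and it rests on compound 1 sitting at the limit of > 1000 nM in this assay, at which 1 of the 2 values shown sits, rather than on a second number. Compound 3 `O=C(CSc1nc2c(c(=O)n1-c1ccccc1)SCC2)Nc1ccc(N2CCCCC2)cc1` differs from compound 2 by piperidin-1-yl in place of phenyl on an aromatic carbon. This moves back toward a nitrogen-linked group like that of compound 1, though the piperidin-1-yl is a ring rather than an open chain, so a rise in the number is expected, because an at least 1300-fold lower number from compound 1 to compound 2 (3.12 log units; beyond the scatter) showed how much the phenyl mattered. For compound 3 the expected step is a 130-fold higher number from compound 2 to compound 3 (2.12 log units; beyond the scatter). Compound 3 is therefore estimated at 100 nM, within a range from 10 nM to 1000 nM.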

Compound 3, half-maximal effective concentration: 30 nM
Compound 3: middle estimate off by 3.3-fold (0.52 log units), on the high side, and the stated range covers the measured number.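

A nitrogen-attached group at this position need not lose the effect altogether: piperidin-1-yl in place of dimethylamino gives an at least 33-fold lower number from compound 1 to compound 3 (1.52 log units; beyond the scatter). Even so, phenyl and piperidin-1-yl are far from interchangeable in this assay, although each brings the same number of heavy atoms, with a 40-fold higher number from compound 2 to compound 3 (1.60 log units; beyond the scatter). The comparison with compound 1 therefore gives only a minimum size for that step, and it rests on a limit rather than on a second number: the limit of > 1000 nM in this assay, at which 1 of the 3 values shown sits.

The compounds shown do not separate the loss of the aromatic ring from the arrival of the ring nitrogen, a question that a cyclohexyl group, a non-aromatic ring of carbon only, or a pyridyl group, an aromatic ring with nitrogen, could help to settle. Going by these compounds, how a morpholine ring would behave at this position also remains open.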